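A few compounds are considered here, and "the series" means these few. Any claim that something is new, unique, unknown or untested is made for them only; others in the source may bear on it.

Compound 1 `CCC(C)(C)Cc1c[nH]c(CCc2ccc(-c3ccncc3)cc2)n1`: in an in vitro assay on CHO cells for displacement of a labelled ligand from Bombesin receptor subtype-3 (Homo sapiens), read by scintillation counting, with a stated time of 2 h (a lower number here means a stronger inhibitor, a higher number a weaker inhibitor), compound 1 gives 101 nM.
Compound 2 `CCC(C)(C)Cc1c[nH]c(CCc2ccc(-c3ccccc3C(=O)O)cc2)n1`: in this assay compound 2 gives 11 nM.
Compound 3 `c1ccc(-c2ccc(CCc3nc(CC4CCCC4)c[nH]3)cc2)nc1`: in this assay compound 3 gives 177 nM.

Compound 2 stands lowest of the three numbers in this assay; compound 1 is its nearest neighbour and compound 3 the furthest, both well beyond the scatter. Compound 4 `CCC(C)(C)Cc1c[nH]c(CCc2ccc(-c3cccnc3)cc2)n1` is not yet measured. It differs from compound 2 in one place: pyridin-3-yl in place of 2-carboxyphenyl on an aromatic carbon. Within the data shown here, the only measured step that bears on this change is the one from compound 1 to compound 2, where 2-carboxyphenyl replaced pyridin-4-yl and the number fell, a 9.2-fold lower number from compound 1 to compound 2 (0.96 log units; beyond the scatter). Compound 4 reverses that kind of exchange, putting a pyridyl group back in place of the 2-carboxyphenyl, so a rise of about that size is expected. Among the measured compounds shown here, compound 3, carrying pyridin-2-yl together with a different side chain, also sits well above compound 2, though no single step links it here. For compound 4 in this assay the expected step is a 9.1-fold higher number from compound 2 to compound 4 (0.96 log units; beyond the scatter), with an estimate of 100 nM and a range from 40 nM to 250 nM.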

Compound 4, half-maximal inhibitory concentration: 7.5 nM
The estimate for compound 4 lay 13-fold (1.12 log units) above the measured number; the whole stated range lies above it.
By their numbers in this assay, from the lowest: compounds 4 and 2 (each within the scatter of the next); then compounds 1 and 3 (each within the scatter of the next).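

In this assay, the 2-carboxyphenyl group proves not to be needed for a low number: pyridin-3-yl, which has no carboxyl group, gives a result within the scatter of it (a 1.5-fold lower number from compound 2 to compound 4 (0.17 log units; within the scatter)). The identity of the pyridyl group matters at this place on the ring, as the exchange of pyridin-4-yl for pyridin-3-yl alone gives a large change (a 13-fold lower number from compound 1 to compound 4 (1.13 log units; beyond the scatter)), so the earlier gain cannot be read as a contrast between pyridyl and 2-carboxyphenyl in general. No measurement on hand explains this difference between the two pyridyl groups.

Going by these compounds, compound 3 differs from these compounds in two places, so the effect of pyridin-2-yl alone remains unknown. On these data alone, it also remains open whether an unsubstituted phenyl ring, or a phenyl ring bearing an amine, would fit this place equally well.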